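This account rests on a few compounds, and the source may have more. Where it says the series, first, only, none or still open, it means among the compounds named here.

Measured compounds:
compound 1 `COc1ccc(NS(=O)(=O)/C=C/c2c(F)c(F)c(F)c(F)c2F)cc1N` with 75000 nM in a functional assay on K562 cells (Homo sapiens) for cytotoxicity, read by trypan blue exclusion, with a stated time of 96 h; a higher number here means a weaker inhibitor, a lower number a stronger inhibitor; compound 2 `COc1cc(OC)c(/C=C/S(=O)(=O)Nc2ccc(OC)c(OP(=O)(O)O)c2)c(OC)c1` with 7.5 nM in this assay.

Among the compounds with values here, compound 2 holds the lower of the two numbers measured so far. Within the data shown here, its only neighbour, compound 1, sits at 75000 nM in this assay, a gap far beyond the usual scatter of repeated measurements; no single-point step connects the two structures, so the pair shows only that the two values lie very far apart.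

Compound 3 `COc1cc(OC)c(/C=C/S(=O)(=O)Nc2ccc(OC)c(NC(C(=O)O)c3ccc(Br)cc3)c2)c(OC)c1` has not yet been measured. It departs from compound 2 at one place: a group of 12 heavy atoms (8 carbon, 1 nitrogen, 2 oxygen, 1 bromine; one six-membered aromatic ring of carbon only) in place of a group of 5 heavy atoms (4 oxygen, 1 phosphorus; no ring), on an aromatic carbon. The group that leaves carries no ring, while the group that enters brings one six-membered aromatic ring of carbon only and a bromine.

Among the measured compounds shown here, no measured step informs this change directly. Compound 2 already stands at a low number, and the change keeps the rest of the shared core untouched, so a step of modest size is expected, a 2.0-fold higher number from compound 2 to compound 3 (0.30 log units; within the scatter), if anything in the direction of a somewhat higher number, and possibly within the scatter. Compound 3 is therefore estimated at 15 nM, with a plausible range from 3 nM to 100 nM.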

Compound 3, half-maximal inhibitory concentration: 75 nM
Estimate against measurement, compound 3: 5.0-fold (0.70 log units) below; low and high end bracket the measured number.
By their numbers in this assay, from the lowest: compound 2; then compound 3; then compound 1.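

Within the data shown here, exchanging the group of 5 heavy atoms (4 oxygen, 1 phosphorus; no ring) for ((4-bromophenyl)(carboxy)methyl)amino, on the aromatic carbon ortho to a methoxy group, gives a 10-fold higher number from compound 2 to compound 3 (1.00 log units; beyond the scatter) in this assay, the first step that can be read at this position. The number therefore responds to what this position carries, yet with a six-membered aromatic ring and a bromine in the entering group, compound 3 still reads 75 nM in this assay, so a much larger group is accepted here without the value being lost altogether. Nothing available bears on why the step has this size.

The entering group differs from the leaving one in several features at once, so the compounds shown cannot separate what the bromine, the aromatic ring and the carboxylic acid each contribute. As far as these compounds go, whether a plain amine or a hydroxyl group at this position, or a chlorine in place of the bromine, would read nearer compound 2 or nearer compound 3 also remains open.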